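The source may report more compounds than this note shows. Statements on the series, on what has been measured and on what is new or still open speak of the compounds shown alone.

Measured compounds:
compound 1 `CC(=O)N[C@@H]1CCN(c2cc(C)nn3c(-c4ccc(OC(F)(F)F)cc4)c(C)nc23)C1` — > 95%
compound 2 `COc1ccc(-c2c(C)nc3c(N4CC[C@@H](NC(=O)OC5CCCCC5)C4)cc(C)nn23)cc1OC` — > 95%

Both values come from an ADME assay on microsomes from liver (Mus musculus) for metabolic stability, read by LC-MS, with NADPH named in the record, with a stated time of 60 min, tested at 1 uM, in the absence of a further agent; on this read-out higher numbers stand for a more stable compound and lower numbers for a less stable compound. For compound 1 the value > 95% is a limit of the assay rather than a number. For compound 2 the value > 95% is likewise a limit and not a number. Among the measured compounds shown here, compound 2 thus stands at the upper edge of what this assay reports, together with the only other value shown, as the limit of > 95% in this assay, at which 2 of the 2 values shown sit, records; no step between measured compounds is available, so no measured size can be carried over.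

Compound 3 `COc1ccc(-c2c(C)nc3c(N4CC[C@@H](N=[N+]=[N-])C4)cc(C)nn23)cc1OC` is not yet measured. It differs from compound 2 by azido in place of (cyclohexyloxycarbonyl)amino on a saturated ring carbon. With both measured values at the limit, the expectation is a change of no size beyond the scatter, in no particular direction. The expected step is a number at least 5 percentage points lower from compound 2 to compound 3 (that floor lies within the scatter). Compound 3 is estimated at 90%, with a range from 70% to 98%.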

Compound 3, percent of the compound remaining: > 95%
Compound 3: a limit, no number (the forecaster's own chance of this, stated with the estimate: 55%); middle value at least 5 percentage points away from the limit.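

In this assay compound 3 gives > 95%, a limit and not a number. No size can be read for the change from compound 2 to compound 3, as the series sits at: the limit of > 95% in this assay, at which 3 of the 3 values shown sit.

The compounds shown leave open whether azido and (cyclohexyloxycarbonyl)amino on the saturated ring carbon differ at all in the percent of compound remaining.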